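Meta-Chloro Analogue of an Indolylazo Benzanilide

The compounds below may be only part of what the source reports. "The series", "measured", "known", "first", "only" and "open" are said of these compounds alone.

Compound 1 `O=C(Nc1ccccc1)c1ccc(/N=N\c2c[nH]c3ccccc23)cc1` is the parent of this small set. Within the data shown here, in a functional assay on MCF7 cells (Homo sapiens) for inhibition, read by MTT assay, with a stated time of 72 h (a lower number here means a stronger inhibitor, a higher number a weaker inhibitor), compound 1 gives 147000 nM, the highest of the three numbers measured so far. Its nearest neighbour is compound 3 `O=C(Nc1ccccc1Cl)c1ccc(/N=N\c2c[nH]c3ccccc23)cc1`, which in this assay gives 112000 nM, a step of a 1.3-fold lower number from compound 1 to compound 3 (0.12 log units; within the scatter). Compound 2 `Cc1ccc(NC(=O)c2ccc(/N=N\c3c[nH]c4ccccc34)cc2)cc1` gives 42400 nM in this assay, a step of a 3.5-fold lower number from compound 1 to compound 2 (0.54 log units; beyond the scatter) from compound 1; between compound 2 and compound 3 the step is a 2.6-fold higher number from compound 2 to compound 3 (0.42 log units; beyond the scatter).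

Compound 4 `O=C(Nc1cccc(Cl)c1)c1ccc(/N=N\c2c[nH]c3ccccc23)cc1` is the next analogue. It differs from compound 1 by chloro in place of hydrogen on an aromatic carbon, the chloro now sitting meta to a large group. Among the measured compounds shown here, the step that bears most directly on it is the one from compound 1 to compound 3, where chloro entered the same ring at another carbon and gave a 1.3-fold lower number from compound 1 to compound 3 (0.12 log units; within the scatter), within the scatter. Only the methyl of compound 2 moved the number clearly. A small drop, if any, is therefore expected for compound 4 in this assay, a step of about a 1.5-fold lower number from compound 1 to compound 4 (0.17 log units; within the scatter). Compound 4 is thus estimated at 100000 nM, in the range 50000 nM to 200000 nM.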

Compound 4, half-maximal inhibitory concentration: 82700 nM
The estimate for compound 4 lay 1.2-fold (0.08 log units) above the measured number; the measured number falls inside the stated range.
By their numbers in this assay, from the lowest: compounds 2, 4, 3 and 1 (each within the scatter of the next, the first and the last beyond it).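

In this assay, among these compounds, chloro meta to a large group leaves the number within the scatter of the parent (a 1.8-fold lower number from compound 1 to compound 4 (0.25 log units; within the scatter)), so this carbon, like the one carrying chloro in compound 3, shows no clear effect of the change. Moving the chloro makes no clear difference either (a 1.4-fold lower number from compound 3 to compound 4 (0.13 log units; within the scatter)), and the 2-chlorophenyl and 3-chlorophenyl analogues cannot be told apart in this assay. Compound 3 stands beyond the scatter of compound 2 (a 2.6-fold higher number from compound 2 to compound 3 (0.42 log units; beyond the scatter)), whereas compound 4 does not (a 2.0-fold higher number from compound 2 to compound 4 (0.29 log units; within the scatter)), although compounds 3 and 4 themselves remain within the scatter of each other.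

Going by these compounds, it remains open how a methyl, a methoxy or an amine would read on this same carbon. On these data alone, whether a carboxylic acid on this ring would move the number is also open. Nothing measured here offers a reason for any of these steps.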